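This account rests on a few compounds, and the source may have more. Where it says the series, first, only, none or still open, it means among the compounds named here.

Series notes. The shared core carries a side chain whose terminal group varies. Compound 1 `CN(CCNCc1cn(-c2ccc(Cl)cc2)nn1)CCNc1ccnc2cc(Cl)ccc12` and compound 2 `CN(CCNCc1cn(-c2ccc(Br)cc2)nn1)CCNc1ccnc2cc(Cl)ccc12` bear an aryl group on the aromatic nitrogen; compound 3 `CN(CCNCc1cn(CCC(=O)Nc2ccccn2)nn1)CCNc1ccnc2cc(Cl)ccc12` carries a 2-((pyridin-2-yl)carbamoyl)ethyl chain there instead. In a functional assay on HCC827 cells (Homo sapiens) for antiproliferative activity, read by sulforhodamine B assay, with a stated time of 72 h (on this read-out higher numbers stand for weaker inhibition and lower numbers for stronger inhibition), compound 1 gives 9500 nM. In this assay compound 2 gives 11000 nM; the step of a 1.2-fold higher number from compound 1 to compound 2 (0.06 log units; within the scatter) is within the scatter. For compound 3, this assay reports only a limit, > 200000 nM; this is the limit of > 200000 nM in this assay, at which 1 of the 3 values shown sits. So compound 3 stands at the weak end of the values shown: the steps of an at least 21-fold higher number from compound 1 to compound 3 (1.32 log units; beyond the scatter) and an at least 18-fold higher number from compound 2 to compound 3 (1.25 log units; beyond the scatter) are both large losses, and no number is known for it.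

Compound 4 `CN(CCNCc1cn(CCCn2nn[nH]c2=O)nn1)CCNc1ccnc2cc(Cl)ccc12` keeps a chain on the aromatic nitrogen and differs from compound 3 by a group of 7 heavy atoms (2 carbon, 4 nitrogen, 1 oxygen; one five-membered aromatic ring with 4 hetero atoms) in place of a group of 9 heavy atoms (6 carbon, 2 nitrogen, 1 oxygen; one six-membered aromatic ring with 1 hetero atom), on a saturated chain carbon, two bonds along the chain from an aromatic nitrogen. Among the compounds with values here, no measured step covers this exchange directly; the only steps that bear on it are the two losses above, which show that a chain in place of the aryl group on that nitrogen leaves the activity beyond the range measured. Compound 4 is another such chain, so no step beyond the scatter is expected in this assay in either direction, a number no higher from compound 3 to compound 4 (the limit leaves the size open), and the likeliest outcome is again a limit. Compound 4 is estimated at 200000 nM, range 50000 nM to 600000 nM.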

Compound 4, half-maximal inhibitory concentration: > 200000 nM
Compound 4 gave a limit, no number; the forecaster's own chance of this, stated with the estimate: 70%; the middle value lies on the limit itself.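

In this assay compound 4 again gives a limit and not a number, as compound 3 does: the limit of > 200000 nM in this assay, at which 2 of the 4 values shown sit.

The loss therefore does not belong to the (pyridin-2-yl)carbamoyl group alone: with a five-membered aromatic ring with 4 hetero atoms at the end of the chain, an at least 21-fold higher number from compound 1 to compound 4 (1.32 log units; beyond the scatter) and an at least 18-fold higher number from compound 2 to compound 4 (1.25 log units; beyond the scatter) are large losses as well. In the four compounds shown, both aryl groups on the aromatic nitrogen give measurable values and both chains give limits, with no compound against this; the step between the two chains cannot be read, so any difference between their end groups stays hidden.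

Still open, on these data alone, is whether the loss goes with the saturated chain itself or with the end groups it carries; a benzyl group on the aromatic nitrogen, or a chain ending in an amine or a carboxylic acid, would bear on that. Also open, as far as these compounds go, is how the aryl side behaves beyond 4-chlorophenyl and 4-bromophenyl, for instance with an unsubstituted phenyl or a 4-methoxyphenyl group.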